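A few compounds are considered here, and "the series" means these few. Any claim that something is new, unique, unknown or untested is made for them only; others in the source may bear on it.

Working notes on the series.

Compound 1 has the structure `Cc1ccc(-c2noc3c2CCNCC3)cc1`. In an assay on cells for displacement of a labelled ligand from 5-hydroxytryptamine receptor 1B (Homo sapiens), read by scintillation counting, with a stated time of 1.5 h (a lower number here means a stronger inhibitor, a higher number a weaker inhibitor), compound 1 gives > 10000 nM, which is a limit of the assay and not a number. Compound 2 has the structure `Clc1ccc(-c2noc3c2CCNCC3)cc1`, with chloro in place of methyl on an aromatic carbon. In this assay compound 2 gives > 10000 nM, again a limit of the assay. The step that the two limits leave unreadable from compound 1 to compound 2 therefore cannot be read, and compound 2 stands only at that limit; both values shown sit there, as the limit of > 10000 nM in this assay, at which 2 of the 2 values shown sit, records.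

Compound 3 has the structure `Fc1ccc(-c2noc3c2CCNCC3)cc1`; it differs from compound 2 in this way: fluoro in place of chloro on an aromatic carbon. Within the data shown here, no measured step bears on this change with a readable size. Given that compound 2 sits at the limit, compound 3 is expected to sit near it too, with the step that the limit leaves unreadable from compound 2 to compound 3 expected. Compound 3 is estimated at 15000 nM in this assay, within 4000 nM to 60000 nM.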

Compound 3, inhibition constant: > 10000 nM
Compound 3 ended at the assay's limit; the forecaster's own chance of this, stated with the estimate: 85%; the middle value lies beyond the limit too.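

Among these compounds, no step among compound 1, compound 2 and compound 3 can be read, since each value is a limit of the assay and not a number: the limit of > 10000 nM in this assay, at which 3 of the 3 values shown sit.

The compounds shown leave open whether any group in this place on the shared core gives a readable value in this assay.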